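A few compounds are considered here, and "the series" means these few. Any claim that something is new, unique, unknown or untested is made for them only; others in the source may bear on it.

Compound 1 `CC1=C(c2ccc(C)c(C)c2)S(=O)(=O)N(Cc2ccc(C(=O)N3CCCCC3)cc2)C1=O` and compound 2 `CC1=C(c2ccc3ccccc3c2)S(=O)(=O)N(Cc2ccc(C(=O)N3CCCCC3)cc2)C1=O` share one core. In an ADME assay on RAW264.7 cells (Mus musculus) for cytotoxicity, read by WST assay (on this read-out lower numbers stand for higher toxicity in this test and higher numbers for lower toxicity in this test), compound 1 gives > 100000 nM, which is a limit of the assay rather than a number. In this assay compound 2 gives 47900 nM, the only number shown, reached by the step of an at least 2.0-fold lower number from compound 1 to compound 2 (0.31 log units; beyond the scatter). Compound 3 `CC1=C(c2cc[n+]([O-])cc2)S(=O)(=O)N(Cc2ccc(C(=O)N3CCCCC3)cc2)C1=O` differs from compound 2 by a group of 7 heavy atoms (5 carbon, 1 nitrogen, 1 oxygen; one six-membered aromatic ring with 1 hetero atom) in place of a group of 10 heavy atoms (10 carbon; 2 six-membered aromatic rings of carbon only), on a double-bonded ring carbon. For the measured compounds named here, only that single measured step bears on this change, and it concerns a different group, so the size is uncertain. Compound 3 is expected to move back toward the limit (the limit of > 100000 nM in this assay, at which 1 of the 2 values shown sits), estimated at 90000 nM with a range from 40000 nM to 200000 nM. That expectation means a step of a 1.9-fold higher number from compound 2 to compound 3 (0.27 log units; within the scatter).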

Compound 3, concentration lethal to 50% of the cells: > 100000 nM
Compound 3: only a limit was reported; the forecaster's own chance of this, stated with the estimate: 55%; at least 1.1-fold (0.04 log units) between middle value and limit.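

In this assay, replacing naphthalen-2-yl on the double-bonded ring carbon with a smaller group, a six-membered aromatic ring with 1 hetero atom, gives an at least 2.0-fold higher number from compound 2 to compound 3 (0.31 log units; beyond the scatter), so the lower number seen with compound 2 does not extend to every aromatic group here. The value of compound 3 is a limit of the assay, not a number, and compound 1 sits at the same limit: the limit of > 100000 nM in this assay, at which 2 of the 3 values shown sit.

The two limits leave the step from compound 1 to compound 3 unreadable. Going by these compounds, how a plain phenyl, an amine or a carboxylic acid on this carbon would read stays open.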